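The compounds below may be only part of what the source reports. "The series", "measured", "known", "first", "only" and "open" are said of these compounds alone.

Compound 1 `Cc1oc(-c2ccc(F)cc2)nc1CN1CCC(C(=O)NCCCN2C[C@H](C)C[C@H](C)C2)CC1` and compound 2 `Cc1oc(-c2c(Cl)cccc2Br)nc1CN1CCC(C(=O)NCCCN2C[C@H](C)C[C@H](C)C2)CC1` share one core and differ only in the group on an aromatic carbon of that core. In an ADME assay on Huh7.5.1 cells (Homo sapiens) for cytotoxicity, read by ATP content, with a stated time of 48 h (a lower number here means that less compound is tolerated, a higher number that more compound is tolerated), compound 1 gives 12800 nM. In this assay compound 2 gives 12200 nM, and its number sits alongside the other: a 1.0-fold lower number from compound 1 to compound 2 (0.02 log units; within the scatter) is within the scatter. Compound 3 `CCc1ccccc1-c1nc(CN2CCC(C(=O)NCCCN3C[C@H](C)C[C@H](C)C3)CC2)c(C)o1` carries 2-ethylphenyl in place of 2-bromo-6-chlorophenyl on an aromatic carbon. Among the compounds with values here, the only known step, an exchange of the same group, left this assay unmoved, so no shift beyond the scatter is expected for a 1.0-fold higher number from compound 2 to compound 3 (0.01 log units; within the scatter). Compound 3 is therefore estimated at 12500 nM, with a range of 6000 nM to 26000 nM.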

Compound 3, half-maximal cytotoxic concentration: 9320 nM
Estimate against measurement, compound 3: 1.3-fold (0.13 log units) above; low and high end bracket the measured number.
By their numbers in this assay, from the lowest: compounds 3, 2 and 1 (each within the scatter of the next).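

With 2-ethylphenyl on this aromatic carbon, a group with no halogen now joins the two halogen-bearing phenyl groups, and this assay still shows only a 1.3-fold lower number from compound 2 to compound 3 (0.12 log units; within the scatter) and a 1.4-fold lower number from compound 1 to compound 3 (0.14 log units; within the scatter). Within these compounds, the tolerated concentration therefore does not depend on halogen being present on the phenyl group at this position. No measurement here explains this outcome. Still open, from the compounds shown here alone, is whether a group without a phenyl ring at this carbon, such as an amine, a carboxylic acid or a longer alkyl chain, would give a step beyond the scatter.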